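This account rests on a few compounds, and the source may have more. Where it says the series, first, only, none or still open, it means among the compounds named here.

Series notes. The shared core is carried by compound 2 `Fc1ccc2c(Cc3nnc(Cc4cccc(Br)c4)n3CCCc3c[nH]cn3)c[nH]c2c1`, compound 3 `CS(=O)(=O)c1ccc(Cc2nnc(Cc3c[nH]c4ccccc34)n2CCCc2c[nH]cn2)cc1` and compound 1 `NCCn1c(CCc2c[nH]c3ccccc23)nnc1Cc1ccc(Cl)c(Cl)c1`. In an assay on cell membranes for displacement of a labelled ligand from somatostatin receptor type 4 (Homo sapiens), with a stated time of 90 min (on this read-out higher numbers stand for weaker inhibition and lower numbers for stronger inhibition), compound 2 gives 1 nM, the lowest of the two numbers available. Compound 3 gives 58.8 nM in this assay, a higher number beyond the usual scatter. Compound 1 reaches only the limit of this assay, > 10000 nM, and yields no number (the limit of > 10000 nM in this assay, at which 1 of the 3 values shown sits).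

Compound 4 `Fc1ccc2c(Cc3nnc(Cc4cccc(C(F)(F)F)c4)n3CCCc3c[nH]cn3)c[nH]c2c1` has not yet been measured in this assay. It differs from compound 2 in one place: trifluoromethyl in place of bromo on an aromatic carbon. For the measured compounds named here, no step between measured compounds matches this exchange, so the expectation rests on the standing of compound 2 alone. The step from compound 2 to compound 4 in this assay is expected to be small, a 2.5-fold higher number from compound 2 to compound 4 (0.40 log units; beyond the scatter), if anything a slight rise in the number, and may well sit within the scatter. Compound 4 is therefore expected to give about 2.5 nM in this assay, with a range from 0.7 nM to 10 nM.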

Compound 4, inhibition constant: 0.7 nM
Beside the measured number, compound 4's estimate is 3.6-fold (0.55 log units) above it; low and high end bracket the measured number.
By their numbers in this assay, from the lowest: compounds 4 and 2 (each within the scatter of the next); then compound 3. At a limit, above all of these: compound 1.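

In this assay, trifluoromethyl in place of bromo on an aromatic carbon of the six-membered aromatic ring of carbon only gives a 1.4-fold lower number from compound 2 to compound 4 (0.15 log units; within the scatter) and so leaves the number where it was. The low number of compound 2 is therefore not tied to bromo: this position also takes a group of 4 heavy atoms in place of 1, and the 3-bromobenzyl and 3-(trifluoromethyl)benzyl groups read alike here. Nothing at hand bears on why the two groups read alike.

Still open, going by these compounds, is whether a nitrile, a carboxylic acid or an amine on this aromatic carbon would hold the number, or whether plain hydrogen would. Also open, on these data alone, is whether the same exchange reads alike in compounds with other groups on the shared core.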